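Trifluoromethyl to benzothiophenyl on the shared core

This account rests on a few compounds, and the source may have more. Where it says the series, first, only, none or still open, it means among the compounds named here.

Compound 1 `CCOC(=O)c1cnc(NN2C(=O)C=C(C)C2=O)nc1C(F)(F)F` is the reference point of this small set. In a functional assay on Jurkat cells (Homo sapiens) for inhibition (a higher number here means a weaker inhibitor, a lower number a stronger inhibitor), compound 1 gives 2000 nM, the second highest of the three numbers. Compound 2 `CCOC(=O)c1cnc(N(C(=O)c2ccccc2)N2C(=O)C=C(C)C2=O)nc1C(F)(F)F` gives 830 nM in this assay, and the step of a 2.4-fold lower number from compound 1 to compound 2 (0.38 log units; beyond the scatter) lies beyond the scatter. Compound 3 `CCOC(=O)c1cnc(NN2C(=O)C=C(C)C2=O)nc1Cc1ccccc1` gives 3800 nM, and the step of a 1.9-fold higher number from compound 1 to compound 3 (0.28 log units; within the scatter) stays within the scatter.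

Compound 4 `CCOC(=O)c1cnc(NN2C(=O)C=C(C)C2=O)nc1-c1cc2ccccc2s1` has not yet been measured. The change from compound 1 is 1-benzothiophen-2-yl in place of trifluoromethyl on an aromatic carbon. Going by the values given here, only the step of a 1.9-fold higher number from compound 1 to compound 3 (0.28 log units; within the scatter) touches the same aromatic carbon, where another group also replaced trifluoromethyl and left the number within the scatter of compound 1. The change to compound 2 concerns a nitrogen on an aromatic ring and does not bear on it. Among the compounds with values here, no measured step speaks for a large move in this assay in either direction, so the expected step is a 1.5-fold higher number from compound 1 to compound 4 (0.18 log units; within the scatter), leaning slightly towards a higher number because compound 3 gives 3800 nM. Compound 4 is therefore estimated at 3000 nM in this assay, with a range from 1000 nM to 9000 nM.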

Compound 4, half-maximal inhibitory concentration: 800 nM
Estimate against measurement, compound 4: 3.8-fold (0.57 log units) above; the whole stated range lies above it.
By their numbers in this assay, from the lowest: compounds 4 and 2 (each within the scatter of the next); then compounds 1 and 3 (each within the scatter of the next).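

The aromatic carbon next to the ring nitrogen had shown no step beyond the scatter, but in this assay 1-benzothiophen-2-yl in place of trifluoromethyl gives a 2.5-fold lower number from compound 1 to compound 4 (0.40 log units; beyond the scatter) and so shows that this position can move the number towards stronger inhibition. The comparison with benzyl at the same carbon gives a 4.8-fold lower number from compound 3 to compound 4 (0.68 log units; beyond the scatter) and shows that these two ring-bearing groups are not interchangeable here. No supporting evidence is available to explain either step.

The compounds shown leave open whether the direct ring attachment, the sulfur or the second aromatic ring carries the change, a question that phenyl or thiophen-2-yl at this carbon would help to separate. Also open, as far as these compounds go, is whether benzoyl on the nitrogen, as in compound 2, would add to the step seen with 1-benzothiophen-2-yl.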